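Cytotoxicity series: longer ether chain replacing chloro

The source may report more compounds than this note shows. Statements on the series, on what has been measured and on what is new or still open speak of the compounds shown alone.

Compound 1 `Nc1ccc(-c2cc(=O)c3c(N)c(F)c(Br)c(F)c3o2)cc1F`, compound 2 `Nc1ccc(-c2cc(=O)c3c(N)c(F)c(Cl)c(F)c3o2)cc1F` and compound 3 `COCc1c(F)c(N)c2c(=O)cc(-c3ccc(N)c(F)c3)oc2c1F` share one core and differ only at one aromatic carbon, carrying bromo, chloro or methoxymethyl. In a functional assay on HeLa cells (Homo sapiens) for cytotoxicity, read by neutral red uptake, with a stated time of 3 days (on this read-out higher numbers stand for weaker inhibition and lower numbers for stronger inhibition), compound 1 gives > 100000 nM, which is a limit of the assay and not a number. Compound 2 gives > 100000 nM in this assay, again a limit. Compound 3 gives > 100000 nM in this assay, also a limit. Compound 2 therefore stands at the same limit as the other two measured compounds, with no number to rank it. The measured steps a step that the two limits leave unreadable from compound 1 to compound 2, a step that the two limits leave unreadable from compound 1 to compound 3 and a step that the two limits leave unreadable from compound 2 to compound 3 are all unreadable in size because the limit of > 100000 nM in this assay, at which 3 of the 3 values shown sit, fixes every value shown.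

Compound 4 `CCCCCCOCc1c(F)c(N)c2c(=O)cc(-c3ccc(N)c(F)c3)oc2c1F` differs from compound 2 in one place: (hexyloxy)methyl in place of chloro on an aromatic carbon. The nearest measured change, from compound 2 to compound 3, also swaps chloro for an ether-bearing chain at this carbon and gives no readable size. Among the measured compounds shown here, no measured step offers a direction, so the expected step that the limit leaves unreadable from compound 2 to compound 4 is none beyond the scatter, with the expectation that compound 4 again sits at the limit. Compound 4 is accordingly estimated at 150000 nM, within 50000 nM to 500000 nM.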

Compound 4, half-maximal inhibitory concentration: > 100000 nM
Compound 4 gave a limit, no number; the forecaster's own chance of this, stated with the estimate: 85%; the middle value is on the limit's open side.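

Among the compounds shown here, no step among compound 1, compound 2, compound 3 and compound 4 can be read in this assay, since each result is a limit of the assay and not a number: the limit of > 100000 nM in this assay, at which 4 of the 4 values shown sit.

The compounds shown leave open how far apart the four lie in this assay, and whether any group at this aromatic carbon gives a measurable value.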